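The source may report more compounds than this note shows. Statements on the series, on what has been measured and on what is new or still open speak of the compounds shown alone.

Compound 2 `CCC[C@@H](O)C1=C(Br)/C(=C/Br)OC1=O` gives 0.3 ug/mL in a functional assay on Lu1 cells (Homo sapiens) for cytotoxicity (on this read-out lower numbers stand for an effect already at smaller amounts and higher numbers for an effect only at larger amounts of compound), the lowest of the two numbers measured. Compound 1 `CCC[C@@H](O)C1=C(Br)/C(=C/I)OC1=O` gives 1.3 ug/mL in this assay, and the step of a 4.3-fold lower number from compound 1 to compound 2 (0.64 log units; beyond the scatter) shows that swapping the halogen at that position mattered. Compound 3 `CCC[C@@H](O)C1=C(Br)/C(=C/Cl)OC1=O` carries one further change: chloro in place of bromo on a double-bonded chain carbon bound to a double-bonded ring carbon. Among the compounds with values here, only that single halogen step bears on it, so it gives little ground for predicting whether a chloro continues the trend or flattens it. Compound 3 is therefore expected near 0.3 ug/mL, between 0.08 ug/mL and 1.2 ug/mL. The expected step of no change at the digits printed from compound 2 to compound 3 (within the scatter) is thus small, within the scatter.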

Compound 3, concentration for half-maximal effect: 1 ug/mL
For compound 3 the middle estimate is 3.3-fold (0.52 log units) below the measured one, and the stated range covers the measured number.
By their numbers in this assay, from the lowest: compound 2; then compounds 3 and 1 (each within the scatter of the next).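

In this assay, bromo is the best of the three halogens on this double-bonded chain carbon, since replacing it with chloro gives a 3.3-fold higher number from compound 2 to compound 3 (0.52 log units; beyond the scatter). Chloro and iodo cannot be told apart, with a 1.3-fold lower number from compound 1 to compound 3 (0.11 log units; within the scatter), so the read-out does not change steadily from one halogen to the next; only bromo stands out. Nothing available here explains this preference for bromo. Still open, as far as these compounds go, is whether fluoro or a nitrile on this carbon would match bromo, and whether bromo keeps its lead with a longer chain elsewhere on the shared core.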